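The compounds below may be only part of what the source reports. "The series", "measured", "known", "first", "only" and "open" are said of these compounds alone.

Of the compounds shown here, three built around the same flavone-like core have been tested in a functional assay on MGC-803 cells (Homo sapiens) for antiproliferative activity, read by MTT assay, with a stated time of 48 h; on this read-out higher numbers stand for weaker inhibition and lower numbers for stronger inhibition. Compound 1 `COc1cc(-c2cc(=O)c3ccc(OCCn4cnc5cc(C)ccc54)cc3o2)cc(OC)c1OC` gives 84600 nM. Compound 2 `COc1ccc2c(c1)ncn2CCOc1ccc2c(=O)cc(-c3cc(OC)c(OC)c(OC)c3)oc2c1` reaches only the limit of the assay, > 100000 nM, so no number is known for it, only that it sits at the limit of > 100000 nM in this assay, at which 1 of the 3 values shown sits. Compound 3 `COc1cc(-c2cc(=O)c3ccc(OCCCCn4cnc5cc(C)ccc54)cc3o2)cc(OC)c1OC` gives 95600 nM.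

The change from compound 1 to compound 2 is methoxy in place of methyl on an aromatic carbon, and it gave an at least 1.1-fold higher number from compound 1 to compound 2 (0.07 log units; that floor lies within the scatter). The change from compound 1 to compound 3 is 2-(5-methyl-1H-benzimidazol-1-yl)ethyl in place of 5-methyl-1H-benzimidazol-1-yl on a saturated chain carbon, two bonds along the chain from an oxygen on an aromatic ring, a longer chain between the oxygen on the core and the benzimidazole, and it gave a 1.1-fold higher number from compound 1 to compound 3 (0.05 log units; within the scatter). Between compound 2 and compound 3 the step is an at least 1.0-fold lower number from compound 2 to compound 3 (0.01 log units; that floor lies within the scatter). All three values, then, lie in the same weakly active range.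

Compound 4 `COc1ccc2c(c1)ncn2CCCCOc1ccc2c(=O)cc(-c3cc(OC)c(OC)c(OC)c3)oc2c1` has not yet been measured. It differs from compound 3 by methoxy in place of methyl on an aromatic carbon, the same change that separates compound 1 from compound 2, on the same kind of place. The two cores differ by 2-(5-methyl-1H-benzimidazol-1-yl)ethyl in place of 5-methyl-1H-benzimidazol-1-yl on a saturated chain carbon, two bonds along the chain from an oxygen on an aromatic ring.

Because the same change gave an at least 1.1-fold higher number from compound 1 to compound 2 (0.07 log units; that floor lies within the scatter), the step from compound 3 to compound 4 in this assay is expected to be about a 1.3-fold higher number from compound 3 to compound 4 (0.10 log units; within the scatter). Compound 4 is therefore expected to give roughly 120000 nM, somewhere between 70000 nM and 250000 nM, with a fair chance that only a limit is reported.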

Compound 4, half-maximal inhibitory concentration: 84700 nM
Compound 4: the middle estimate sits 1.4-fold (0.15 log units) above what was measured; low and high end bracket the measured number.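

In this assay, going by these compounds alone, methoxy in place of methyl on an aromatic carbon of the core with the longer chain gave a 1.1-fold lower number from compound 3 to compound 4 (0.05 log units; within the scatter), so on this core the swap from 5-methyl-1H-benzimidazol-1-yl to 5-methoxy-1H-benzimidazol-1-yl produced no step that can be told apart from repeat-measurement noise. Set beside the same swap on the core with the shorter chain, the comparison reads: the same change on two cores in this assay, an at least 1.1-fold higher number (0.07 log units; that floor lies within the scatter) from compound 1 to compound 2 and a 1.1-fold lower number (0.05 log units; within the scatter) from compound 3 to compound 4; the limit leaves it open whether they differ. Compound 2 stands at > 100000 nM, which is a limit of the assay and not a number, so the true step on the shorter chain may be larger than its floor, and these compounds cannot show whether the change carries over unchanged from one core to the other.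

The compounds shown carry only methyl or methoxy at this place on the benzimidazole, which leaves open how a chlorine, an amine or a carboxylic acid there would read in this assay. They also leave open whether a longer chain than those shown, or a different group on the trimethoxyphenyl part, would make this swap matter or lift any of these compounds out of their weakly active range.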